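The compounds below may be only part of what the source reports. "The series", "measured", "known", "first", "only" and "open" are said of these compounds alone.

Working notes on the series. The shared core carries an aromatic group on a carbon with a double bond to nitrogen, and compound 1 `COc1ccccc1-c1nnc(-c2ccc(C(=O)N/N=C/c3ccc([N+](=O)[O-])cc3)cc2)o1`, compound 2 `COc1ccccc1-c1nnc(-c2ccc(C(=O)N/N=C/c3ccccc3[N+](=O)[O-])cc2)o1` and compound 3 `COc1ccccc1-c1nnc(-c2ccc(C(=O)N/N=C/c3ccc(F)cc3)cc2)o1` differ only in that group. In an ADME assay on THP-1 cells (Homo sapiens) for cytotoxicity (a lower number here means a stronger inhibitor, a higher number a weaker inhibitor), compound 1 gives 203000 nM, compound 2 gives 161000 nM and compound 3 gives 427000 nM. Compound 3 therefore stands at the highest number of the three measured: both a 2.1-fold higher number from compound 1 to compound 3 (0.32 log units; beyond the scatter) and a 2.7-fold higher number from compound 2 to compound 3 (0.42 log units; beyond the scatter) lie beyond the scatter, whereas a 1.3-fold lower number from compound 1 to compound 2 (0.10 log units; within the scatter) does not.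

Compound 4 `COc1ccccc1-c1nnc(-c2ccc(C(=O)N/N=C/c3cccnc3)cc2)o1` has not been measured. Against compound 3 the change is pyridin-3-yl in place of 4-fluorophenyl on a carbon with a double bond to nitrogen. Within the data shown here, the steps that bear on it are the three that alter the same aromatic group, and none of them is large. Among the measured compounds shown here, no measured step exchanges this ring for a ring holding a hetero atom, so the direction is open; given that compound 3 already gives the top number of the set, the expected step in this assay is small and, if anything, toward a lower number. Compound 4 is expected to give about 300000 nM, within 120000 nM to 700000 nM, which corresponds to an expected 1.4-fold lower number from compound 3 to compound 4 (0.15 log units; within the scatter).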

Compound 4, half-maximal inhibitory concentration: 167000 nM
Estimate against measurement, compound 4: 1.8-fold (0.25 log units) above, within the range that was stated.
By their numbers in this assay, from the lowest: compounds 2, 4 and 1 (each within the scatter of the next); then compound 3.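

In this assay, among these compounds, pyridin-3-yl is the first ring at this position to hold a hetero atom, and its exchange for 4-fluorophenyl gives a 2.6-fold lower number from compound 3 to compound 4 (0.41 log units; beyond the scatter), a step beyond the scatter. Against the two nitro-bearing rings, the same ring gives a 1.0-fold higher number from compound 2 to compound 4 (0.02 log units; within the scatter) and a 1.2-fold lower number from compound 1 to compound 4 (0.08 log units; within the scatter), both within the scatter, so the series now shows that a ring without a nitro group can sit level with the nitro-bearing pair, and the 4-fluorophenyl ring is the only one of the four that stands apart. No supporting data bear on why the 4-fluorophenyl ring differs from the other three, so the step stands here as an observation only.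

The compounds shown leave open whether an amine or a carboxylic acid on the aromatic ring at this position would stay level with the three lower compounds or move toward compound 3. They also leave open whether a longer chain in place of the aromatic ring on the carbon with a double bond to nitrogen would move the number further than any step seen so far.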